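Small Step Expected at the Chain of Compound 3

The source may report more compounds than this note shows. Statements on the series, on what has been measured and on what is new or still open speak of the compounds shown alone.

Values in a functional assay on Hep 3B2 cells (Homo sapiens) for cytotoxicity, read by MTT assay, with a stated time of 48 h (a lower number here means a stronger inhibitor, a higher number a weaker inhibitor), are as follows:

- Compound 1 `C=CCCCCCCCCc1n[nH]c(=S)n1N` gives 9200 nM
- Compound 2 `CCCCCCC(O)C/C=C\CCCCCCCC1=NNC2SCC(c3ccccc3)=NN12` gives 6500 nM
- Compound 3 `CCCC/C=C\CCC(O)CCCCCCC1=NNC2SCC(c3ccccc3)=NN12` gives 7360 nM

Compound 3 lies within the scatter of both compound 2 and compound 1, so these values set no order. In compound 4 `C=CCCCCCCCCC1=NNC2SCC(c3ccccc3)=NN12`, but-3-en-1-yl takes the place of 1-hydroxynon-4-en-1-yl on a saturated chain carbon, six bonds along the chain from a carbon with a double bond to nitrogen but-3-en-1-yl in place of 1-hydroxynon-4-en-1-yl on a saturated chain carbon, six bonds along the chain from a carbon with a double bond to nitrogen as the count of the change. For the measured compounds named here, no measured pair isolates this change. Compound 1 at 9200 nM has a different core yet remains within the scatter of the other two. No step beyond the scatter is therefore expected in this assay and no direction is favoured. The expected step is a 1.1-fold lower number from compound 3 to compound 4 (0.02 log units; within the scatter) and stays within the scatter. Compound 4 is estimated at 7000 nM and expected between 3500 nM and 14000 nM here.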

Compound 4, half-maximal inhibitory concentration: 7400 nM
Compound 4: middle estimate off by 1.1-fold (0.02 log units), on the low side, within the range that was stated.
By their numbers in this assay, from the lowest: compounds 2, 3, 4 and 1 (each within the scatter of the next).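

In this assay, but-3-en-1-yl in place of 1-hydroxynon-4-en-1-yl on a saturated chain carbon, six bonds along the chain from a carbon with a double bond to nitrogen, gives a 1.0-fold higher number from compound 3 to compound 4 (0.00 log units; within the scatter) and so leaves the number within the scatter. Read as allyl in place of 4-hydroxydec-1-en-1-yl, seven bonds along the chain from that carbon, the change gives a 1.1-fold higher number from compound 2 to compound 4 (0.06 log units; within the scatter) and again stays within it. At this position, the hydroxyl-bearing chain and the shorter chain therefore cannot be told apart here.

Going by these compounds, whether an amine or a carboxylic acid on this chain would give a step beyond the scatter remains open. No measurement is available that bears on this result.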